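Series notes: aryl change on compound 3, methylated core

A few compounds are considered here, and "the series" means these few. Any claim that something is new, unique, unknown or untested is made for them only; others in the source may bear on it.

Measured so far:
- compound 1, `O=C(Nc1ccc(Oc2ccnc3[nH]ccc23)cc1)c1nn(-c2ccc(Br)cc2)ccc1=O`: 8040 nM
- compound 2, `O=C(Nc1ccc(Oc2ccnc3[nH]ccc23)c(F)c1)c1nn(-c2ccc(Cl)c(C(F)(F)F)c2)ccc1=O`: 5500 nM
- compound 3, `Cn1ccc2c(Oc3ccc(NC(=O)c4nn(-c5ccc(Br)cc5)ccc4=O)cc3)ccnc21`: 23000 nM

In a functional assay on PC-3 cells (Homo sapiens) for cytotoxicity, read by MTT assay, with a stated time of 72 h (on this read-out lower numbers stand for stronger inhibition and higher numbers for weaker inhibition), compound 3 gives 23000 nM, the highest of the three numbers recorded. For the measured compounds named here, its nearest neighbour is compound 1, which in this assay gives 8040 nM, and the only measured step that is a single change, a 2.9-fold higher number from compound 1 to compound 3 (0.46 log units; beyond the scatter), is the one that produced compound 3. Compound 2 in this assay gives 5500 nM; it differs from compound 1 in two places, so its values only show that the chlorinated, trifluoromethylated aryl combined with a fluorinated middle ring gives a lower number than compound 1.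

Compound 4, `Cn1ccc2c(Oc3ccc(NC(=O)c4nn(-c5ccc(Cl)c(F)c5)ccc4=O)cc3)ccnc21`, is compound 3 with one change: 4-chloro-3-fluorophenyl in place of 4-bromophenyl on an aromatic nitrogen. Going by the values given here, no measured step in this assay changes the aryl group on the ring nitrogen alone, so nothing here bears directly on this step. Among the compounds with values here, the one single-change step concerns a different site. With no guidance, the expectation is no step beyond the scatter, a 1.3-fold lower number from compound 3 to compound 4 (0.11 log units; within the scatter). Compound 4 is therefore estimated at 18000 nM in this assay, with a range of 7000 nM to 50000 nM.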

Compound 4, half-maximal inhibitory concentration: 32700 nM
Compound 4: the middle estimate sits 1.8-fold (0.26 log units) below what was measured; measured number inside the range.
By their numbers in this assay, from the lowest: compounds 2 and 1 (each within the scatter of the next); then compounds 3 and 4 (each within the scatter of the next).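

In this assay, 4-chloro-3-fluorophenyl in place of 4-bromophenyl on the aromatic nitrogen gives a 1.4-fold higher number from compound 3 to compound 4 (0.15 log units; within the scatter), so this exchange of halogenated aryl groups on the methylated core produces no readable difference. For the compounds shown here, this is the first single-change reading at this position, since the earlier single-change step concerned only the methyl on the aromatic nitrogen of the shared core, and it shows that the read-out of this methylated series stays put across these two aryl groups, at least for this pair. No available measurement speaks to why the two aryl groups read alike.

Still open, as far as these compounds go, is whether the same aryl exchange would also leave the number unmoved on the unmethylated core of compound 1, as this pair speaks only for the methylated core. Also open, from the compounds shown here alone, is how the series responds at this position to an aryl group carrying something other than halogen, such as an amine or a carboxylic acid, or to a longer chain in place of the aryl ring.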